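Working notes: replacing the 2-bromophenyl group

The source may hold more compounds than are shown below. What is called first, only, known or untested is meant among the compounds shown, and "the series" means these compounds.

In an ADME assay on microsomes from liver (Rattus norvegicus) for metabolic stability (a higher number here means that the compound lasts longer, a lower number that the compound disappears faster), compound 3 `Nc1nc(NCCNc2ncc(-c3ncc[nH]3)c(-c3ccccc3Br)n2)ccc1[N+](=O)[O-]` gives > 0.5 h, which is a limit and not a number. Compound 1 `N#Cc1ccc(-c2nc(NCCNc3ccc([N+](=O)[O-])c(N)n3)ncc2-c2ncc[nH]2)cc1` gives > 0.5 h, also a limit. Compound 2 `FC(F)(F)c1ccc(NCCNc2ncc(-c3ncc[nH]3)c(-c3ccc(Cl)cc3Cl)n2)nc1` gives > 0.5 h, again a limit. The whole set therefore rests on one reading: the limit of > 0.5 h in this assay, at which 3 of the 3 values shown sit. Compound 3 has no measured number from which to place it against the others.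

Compound 4 `Nc1nc(NCCNc2ncc(-c3ncc[nH]3)c(-c3cc(F)c(F)cc3F)n2)ccc1[N+](=O)[O-]` differs from compound 3 in one place: 2,4,5-trifluorophenyl in place of 2-bromophenyl on an aromatic carbon. Here 2,4,5-trifluorophenyl stands in place of 2-bromophenyl on an aromatic carbon of a six-membered aromatic ring with 2 nitrogen, ortho to a 1H-imidazol-2-yl group.

Among the compounds with values here, the only measured step bearing on this change is a step that the two limits leave unreadable from compound 1 to compound 3, where 2-bromophenyl replaces 4-cyanophenyl on an aromatic carbon. That step has no readable size, so it offers no guide to size or direction. No step beyond the scatter is therefore expected in this assay, and no direction is favoured. The estimated step is a step that the limit leaves unreadable from compound 3 to compound 4. A further limit is the most likely report. For compound 4 the expected half-life is 0.8 h, with an estimated range of 0.4 h to 2 h.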

Compound 4, half-life: > 0.5 h
Compound 4: a limit, no number; the forecaster's own chance of this, stated with the estimate: 80%; the middle value lies beyond the limit too.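

In this assay compound 4 gives > 0.5 h, a limit and not a number. No new step can be read from compound 3 to compound 4 or from compound 1 to compound 4. The compounds shown leave open the actual half-life of each compound and any real difference among them, as the series still rests on one reading: the limit of > 0.5 h in this assay, at which 4 of the 4 values shown sit.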